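Hydroxy to methoxy in compound 2

This account rests on a few compounds, and the source may have more. Where it says the series, first, only, none or still open, it means among the compounds named here.

Compound 1 `Nc1nc(N)c2cc(CSC(=S)N3CCN(c4ccccc4)CC3)ccc2n1`: 2970 nM
Compound 2 `Nc1nc(N)c2cc(CSC(=S)N3CCN(c4ccc(O)cc4)CC3)ccc2n1`: 4210 nM

Both compounds were measured in a functional assay on A549 cells (Homo sapiens) for antiproliferative activity, read by MTT assay, with a stated time of 72 h; a lower number here means a stronger inhibitor, a higher number a weaker inhibitor. The pair differs by a 1.4-fold higher number from compound 1 to compound 2 (0.15 log units; within the scatter), so compound 2 cannot be separated from compound 1 on these numbers. The next compound to be measured, compound 3 `COc1ccc(N2CCN(C(=S)SCc3ccc4nc(N)nc(N)c4c3)CC2)cc1`, has methyl in place of hydrogen on an oxygen on an aromatic ring, turning the 4-hydroxyphenyl of compound 2 into 4-methoxyphenyl (methyl in place of hydrogen on an oxygen on an aromatic ring). Going by the values given here, no measured step covers this exact change. The nearest evidence is the step from compound 1 to compound 2, which placed hydroxy on an aromatic carbon and stayed small at a 1.4-fold higher number from compound 1 to compound 2 (0.15 log units; within the scatter). A step beyond the scatter in this assay is therefore not expected, and no direction is favoured. The estimated step is a 1.2-fold lower number from compound 2 to compound 3 (0.08 log units; within the scatter). For compound 3 the expected value is 3500 nM, with an estimated range of 1700 nM to 7500 nM.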

Compound 3, half-maximal inhibitory concentration: 1590 nM
Compound 3: the middle estimate sits 2.2-fold (0.34 log units) above what was measured, outside the stated range (below it).
By their numbers in this assay, from the lowest: compounds 3, 1 and 2 (each within the scatter of the next, the first and the last beyond it).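

In this assay, placing methyl on the oxygen on the aromatic ring produces the first step beyond the scatter among these compounds, though a modest one (a 2.6-fold lower number from compound 2 to compound 3 (0.42 log units; beyond the scatter)), so the hydroxy and methoxy forms of this 4-substituted phenyl can be told apart. The comparison with the unsubstituted phenyl does not separate the compounds (a 1.9-fold lower number from compound 1 to compound 3 (0.27 log units; within the scatter)), and compound 1 is likewise not separated from compound 2, so only the two oxygen-bearing compounds lie beyond the scatter of each other. Nothing given here explains the difference between them.

The compounds shown leave open whether a longer chain on that oxygen, as in ethoxy, would follow methoxy or differ from it. They also leave open how an amine or a carboxylic acid in place of the hydroxy would read in this assay.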